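A few compounds are considered here, and "the series" means these few. Any claim that something is new, unique, unknown or untested is made for them only; others in the source may bear on it.

Measured compounds:
- compound 1, `CCCCCNC(=O)NS(=O)(=O)c1cc(C#N)ccc1Oc1ccc(C)cc1`: 900 nM
- compound 2, `CC(C)(C)NC(=O)NS(=O)(=O)c1cc(C#N)ccc1Oc1ccc(F)cc1`: 4350 nM
- compound 3, `CCCCCNC(=O)NS(=O)(=O)c1cc(C#N)ccc1Oc1ccc(F)cc1`: 9430 nM

In a functional assay on HEK293 cells for antagonist activity at thromboxane A2 receptor (Homo sapiens), read by fluorescence and calcium flux (on this read-out higher numbers stand for weaker inhibition and lower numbers for stronger inhibition), compound 3 gives the highest number of the three. Its nearest neighbour is compound 2 a 2.2-fold higher number from compound 2 to compound 3 (0.34 log units; beyond the scatter); the furthest is compound 1 a 10-fold higher number from compound 1 to compound 3 (1.02 log units; beyond the scatter).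

Compound 4, `CCCCCNC(=O)NS(=O)(=O)c1cc(C#N)ccc1Nc1ccc(F)cc1`, differs from compound 3 in one place: (4-fluorophenyl)amino in place of 4-fluorophenoxy on an aromatic carbon. The linking atom between the two aromatic rings is exchanged, the rest of the molecule being unchanged.

Neither measured step bears on this exchange. The step from compound 1 to compound 3 concerns the substituent on the outer ring, and the step from compound 2 to compound 3 concerns the group on the urea nitrogen; both leave the link between the rings untouched. For the measured compounds named here, there is thus no precedent for the direction or size of the change in this assay.

In this assay compound 4 is therefore expected to land near compound 3, with a step of a 1.2-fold lower number from compound 3 to compound 4 (0.07 log units; within the scatter) that need not exceed the scatter, and the estimate is given a wide range. The estimated value for compound 4 is 8000 nM, between 2000 nM and 30000 nM.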

Compound 4, half-maximal inhibitory concentration: 6780 nM
Beside the measured number, compound 4's estimate is 1.2-fold (0.07 log units) above it; the measured number falls inside the stated range.
By their numbers in this assay, from the lowest: compound 1; then compounds 2, 4 and 3 (each within the scatter of the next, the first and the last beyond it).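

In this assay, the linking atom on this aromatic carbon, para to a cyano group, can change from the oxygen of 4-fluorophenoxy to the nitrogen of (4-fluorophenyl)amino, bringing one more hydrogen-bond donor by count, with a 1.4-fold lower number from compound 3 to compound 4 (0.14 log units; within the scatter). With the fluoro substituent kept, the amino link therefore does not separate compound 4 from compound 3 in this assay, while the exchange of 4-methylphenoxy for (4-fluorophenyl)amino gives a 7.5-fold higher number from compound 1 to compound 4 (0.88 log units; beyond the scatter), a step that alters the linking atom and the outer-ring substituent together. Nothing available explains either result.

Open, going by these compounds, is whether (4-methylphenyl)amino at this position would come close to compound 1 at 900 nM, which would show whether the methyl group keeps its step with an amino link. Also open, on these data alone, is how a sulfur linking atom would compare, and whether tert-butyl on the urea nitrogen would give the same step with an amino link.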